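The source may report more compounds than this note shows. Statements on the series, on what has been measured and on what is new or still open speak of the compounds shown alone.

Two compounds in this series have numbers in an assay on HL-60 cells for agonist activity at vitamin D3 receptor (Homo sapiens), read by microscopy, with a stated time of 96 h (on this read-out higher numbers stand for an effect only at larger amounts of compound and lower numbers for an effect already at smaller amounts), so far. Compound 1 `CCn1c(C(=O)NCC(OC)OC)ccc1C(CC)(CC)c1ccc(OCC(=O)C(C)(C)C)c(C)c1` gives 130 nM in this assay. Compound 2 `CCN(CC)CCCNC(=O)c1ccc(C(CC)(CC)c2ccc(OCC(O)C(C)(C)C)c(C)c2)n1CC` gives 66 nM in this assay, the lower of the two numbers, though its gap to compound 1 lies within the scatter, so the two are not told apart. Compound 3 `CCn1c(C(=O)NCC(OC)OC)ccc1C(CC)(CC)c1ccc(OCC(O)C(C)(C)C)c(C)c1` is the next compound to be measured in this assay. The change from compound 2 to compound 3 is dimethoxymethyl in place of 2-(diethylamino)ethyl on a saturated chain carbon bound to an amide-type nitrogen, that is, the basic amine-bearing chain on the amide is exchanged for a chain that ends in two methoxy groups. The step from compound 2 to compound 3 is expected to be a modest rise in the number, at most slightly beyond the scatter, given as a 1.5-fold higher number from compound 2 to compound 3 (0.18 log units; within the scatter). The expected value for compound 3 in this assay is therefore 100 nM, with a likely range from 40 nM to 250 nM.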

Compound 3, half-maximal effective concentration: 150 nM
Compound 3: the middle estimate sits 1.5-fold (0.18 log units) below what was measured, and the stated range covers the measured number.
By their numbers in this assay, from the lowest: compounds 2, 1 and 3 (each within the scatter of the next, the first and the last beyond it).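

In this assay, putting 2,2-dimethoxyethyl in place of 3-(diethylamino)propyl on the amide gives a 2.3-fold higher number from compound 2 to compound 3 (0.36 log units; beyond the scatter), so this position does respond to the exchange, although the step is modest. The second change, 1-hydroxy-2,2-dimethylpropyl in place of (tert-butyl)carbonyl on a saturated chain carbon bound to an oxygen on an aromatic ring, gives a 1.2-fold higher number from compound 1 to compound 3 (0.06 log units; within the scatter), so these two groups are not told apart at this position. No measurement shown here accounts for either step.

On these data alone, whether a morpholine, a carboxylic acid or a plain butyl chain on the amide would read closer to compound 2 or to compound 3 remains open. Also open, as far as these compounds go, is whether the exchange of (tert-butyl)carbonyl for 1-hydroxy-2,2-dimethylpropyl would read the same with 3-(diethylamino)propyl on the amide.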